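Fluoro Substitution on a Phenyl Ring in Anticonvulsant Mice

A few compounds are considered here, and "the series" means these few. Any claim that something is new, unique, unknown or untested is made for them only; others in the source may bear on it.

Compound 1 `COc1ccc(Cn2cc(CO/N=C/c3c(-c4ccccc4)nc4c(C)cccn34)nn2)cc1` gives 100 mg/kg in a functional assay on the whole organism (strain NMRI) with Mus musculus as the target, with a stated time of 4 h; a higher number here means that more compound is needed for the effect, a lower number that less compound is needed. Compound 2 `COc1ccc(Cn2cc(CO/N=C/c3c(-c4ccc(F)cc4)nc4c(C)cccn34)nn2)cc1` differs from it by fluoro in place of hydrogen on an aromatic carbon, and the step of a 2.5-fold lower number from compound 1 to compound 2 (0.40 log units; beyond the scatter) leaves compound 2 at 40 mg/kg in this assay. Compound 3 `N#Cc1ccc(Cn2cc(CO/N=C/c3c(-c4ccccc4)nc4ccc(Br)cn34)nn2)cc1` has a different core; the difference between the two cores is not broken down here. In this assay compound 3 gives 20 mg/kg, the lowest of the three numbers, though its gap to compound 2 is within the scatter. Compound 4 `N#Cc1ccc(Cn2cc(CO/N=C/c3c(-c4ccc(F)cc4)nc4ccc(Br)cn34)nn2)cc1` differs from compound 3 by fluoro in place of hydrogen on an aromatic carbon, the same change seen between compound 1 and compound 2. Because the earlier step was a 2.5-fold lower number from compound 1 to compound 2 (0.40 log units; beyond the scatter), a similar step a 2.0-fold lower number from compound 3 to compound 4 (0.30 log units; within the scatter) is expected here. Compound 4 is therefore estimated at 10 mg/kg in this assay, between 4 mg/kg and 30 mg/kg.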

Compound 4, minimum effective dose: 100 mg/kg
Beside the measured number, compound 4's estimate is 10-fold (1.00 log units) below it; measured number above the stated range.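

In this assay, the change from phenyl to 4-fluorophenyl did not carry over between the two cores, since a 5.0-fold higher number from compound 3 to compound 4 (0.70 log units; beyond the scatter) runs opposite to the earlier step: the same change on two cores in this assay, a 2.5-fold lower number (0.40 log units; beyond the scatter) from compound 1 to compound 2 and a 5.0-fold higher number (0.70 log units; beyond the scatter) from compound 3 to compound 4, 13-fold (1.10 log units) apart, beyond the scatter of two such steps Within these two pairs, then, the outcome of adding this fluoro depends on the rest of the molecule. The pairs differ in more than one place, including methyl against bromo and methoxy against nitrile, so the data do not show which difference reverses the step, nor why it reverses.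

The compounds shown leave open how the fluoro change behaves with methyl and nitrile together, or with bromo and methoxy together. They also leave open whether a chloro group or an amine in place of the fluoro would follow either direction.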